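The compounds below may be only part of what the source reports. "The series", "measured", "known", "first", "only" and "open" are said of these compounds alone.

In a physicochemical assay for solubility, using the shake flask method, in simulated intestinal fluid, measured as kinetic solubility, with a stated time of 2 h, at 25 degrees C, at pH 6.5 (a lower number here means a less soluble compound, a higher number a more soluble compound), compound 3 (`Cc1noc(-c2nc(C)c3c(c2N)C(=O)N(Cc2ccc(-n4cccn4)cc2)C3=O)n1`) gives < 5000 nM as a limit of the assay, not a number. Compound 1 (`Cc1nc(C(N)=O)c(N)c2c1C(=O)N(Cc1ccccc1)C2=O`) gives < 5000 nM which is likewise a limit. Compound 2 (`CNC(=O)c1nc(C)c2c(c1N)C(=O)N(Cc1ccccc1)C2=O`) gives a measured number of 41000 nM in this assay on the same kind of core.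

Compound 4 (`Cc1noc(-c2nc(C)c3c(c2N)C(=O)N(Cc2ccc(C(F)(F)F)cc2)C3=O)n1`) differs from compound 3 by trifluoromethyl in place of 1H-pyrazol-1-yl on an aromatic carbon of a six-membered aromatic ring of carbon only, para to a large group (trifluoromethyl in place of 1H-pyrazol-1-yl on an aromatic carbon). For the measured compounds named here, the one measured step is an at least 8.2-fold higher number from compound 1 to compound 2 (0.91 log units; beyond the scatter) for methyl in place of hydrogen on an amide-type nitrogen. That is a different change at a different place, so it sets no size for this one. The closer guide is the limit of < 5000 nM in this assay, at which 2 of the 3 values shown sit, and compound 3 is one of those two.

No step beyond the scatter is therefore expected in this assay and no direction is favoured, so a reading at the same limit is the likeliest outcome. The step expected on this estimate is a step that the limit leaves unreadable from compound 3 to compound 4 as a rough figure only. For compound 4 the expected value is 4000 nM with an estimated range from 1500 nM to 12000 nM in this assay.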

Compound 4, solubility: < 5000 nM
Compound 4: a limit, no number; the forecaster's own chance of this, stated with the estimate: 65%; the middle value does not contradict the limit.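

For the compounds shown here, compound 3 and compound 4 both give limits rather than numbers in this assay, so no step between them can be read. The values shown cluster at that limit: the limit of < 5000 nM in this assay, at which 3 of the 4 values shown sit.

The compounds shown leave open whether trifluoromethyl in place of 1H-pyrazol-1-yl on an aromatic carbon changes the reading at all, and in which direction.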